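The source may hold more compounds than are shown below. What is called first, only, known or untested is meant among the compounds shown, and "the series" means these compounds.

Compound 1 `Clc1ccc(C2CC(c3ccc4c(c3)OCCO4)=NN2c2ccccc2)cc1`: 38600 nM. Compound 2 `Clc1cccc(C2CC(c3ccc4c(c3)OCCO4)=NN2c2ccccc2)c1`: 1750 nM. Compound 3 `c1ccc(N2N=C(c3ccc4c(c3)OCCO4)CC2c2ccco2)cc1`: > 100000 nM, a limit of the assay rather than a number.

In a functional assay on WM 266-4 cells (Homo sapiens) for antiproliferative activity, read by MTT assay, with a stated time of 24 h (a lower number here means a stronger inhibitor of growth, a higher number a weaker inhibitor of growth), compound 1 gives the highest of the two numbers; its nearest neighbour is a 22-fold lower number from compound 1 to compound 2 (1.34 log units; beyond the scatter). Compound 3 only reaches (the limit of > 100000 nM in this assay, at which 1 of the 3 values shown sits). Compound 4 `Cc1ccc(C2CC(c3ccc4c(c3)OCCO4)=NN2c2ccccc2)cc1` differs from compound 1 by methyl in place of chloro on an aromatic carbon. Within the data shown here, none of the measured steps exchanges one group for another on the same aromatic carbon: a 22-fold lower number from compound 1 to compound 2 (1.34 log units; beyond the scatter) moves the chloro, while an at least 2.5-fold higher number from compound 1 to compound 3 (0.41 log units; beyond the scatter) and an at least 57-fold higher number from compound 2 to compound 3 (1.75 log units; beyond the scatter) replace the whole ring. Among the measured compounds shown here, no step thus bears directly on methyl in place of chloro, so compound 4 is expected to stay close to compound 1, an estimated step of a 1.0-fold higher number from compound 1 to compound 4 (0.02 log units; within the scatter) with no clear direction beyond the scatter. Compound 4 is estimated at 40000 nM, between 12000 nM and 100000 nM.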

Compound 4, concentration for 50% growth inhibition: 2530 nM
Compound 4: middle estimate off by 16-fold (1.20 log units), on the high side; measured number outside the range, below it.
By their numbers in this assay, from the lowest: compounds 2 and 4 (each within the scatter of the next); then compound 1. At a limit, above all of these: compound 3.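

In this assay, methyl in place of chloro on this aromatic carbon, para to a large group, is a large change in its own right: a 15-fold lower number from compound 1 to compound 4 (1.18 log units; beyond the scatter). The 4-methylphenyl and 3-chlorophenyl rings are not told apart, a 1.4-fold higher number from compound 2 to compound 4 (0.16 log units; within the scatter), so a group at this place need not cost activity. Compound 3 remains a limit of the assay rather than a number, and the step to the 4-methylphenyl ring is an at least 39-fold lower number from compound 3 to compound 4 (1.59 log units; beyond the scatter).

Going by these compounds, how a methoxy group, an amine or a carboxylic acid on this carbon would compare remains open. So does the effect of 3-methylphenyl on the same saturated ring carbon.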